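A few compounds are considered here, and "the series" means these few. Any claim that something is new, unique, unknown or untested is made for them only; others in the source may bear on it.

Measured in a functional assay on ECa-109 cells (Homo sapiens) for cytotoxicity, read by MTT assay, with a stated time of 72 h; a lower number here means a stronger inhibitor, a higher number a weaker inhibitor:
- compound 1 `O=C1C(=Cc2ccc(O)cc2)C(=O)N(c2ccc(Cl)cc2)N1c1ccc(Cl)cc1`: 34200 nM
- compound 2 `COc1ccc(C=C2C(=O)N(c3ccc(Cl)cc3)N(c3ccc(Cl)cc3)C2=O)cc1OC`: > 128000 nM (a limit, not a number)
- compound 3 `COc1ccccc1C=C1C(=O)N(c2ccc(Cl)cc2)N(c2ccc(Cl)cc2)C1=O`: 30400 nM

Compound 3, at 30400 nM, lies within the scatter of compound 1 at 34200 nM. Compound 2 gives only a limit, > 128000 nM. Compound 3 therefore shares the lowest measured position with compound 1.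

Compound 4 `O=C1C(=Cc2c[nH]c3ccccc23)C(=O)N(c2ccc(Cl)cc2)N1c1ccc(Cl)cc1` keeps the shared core and has 1H-indol-3-yl in place of 2-methoxyphenyl, on a double-bonded chain carbon bound to a double-bonded ring carbon: 1H-indol-3-yl in place of 2-methoxyphenyl on a double-bonded chain carbon bound to a double-bonded ring carbon.

Three measured steps change the group at this same place. Exchanging 4-hydroxyphenyl for 2-methoxyphenyl gives a 1.1-fold lower number from compound 1 to compound 3 (0.05 log units; within the scatter), so that exchange stays within the scatter. Exchanging it for 3,4-dimethoxyphenyl gives an at least 3.7-fold higher number from compound 1 to compound 2 (0.57 log units; beyond the scatter). Exchanging 3,4-dimethoxyphenyl for 2-methoxyphenyl gives an at least 4.2-fold lower number from compound 2 to compound 3 (0.62 log units; beyond the scatter). Group swaps here can therefore do nothing measurable or can shift the number clearly, and no measured compound carries 1H-indol-3-yl.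

No clear direction can be drawn from these steps, so the expected change is none beyond the scatter, with a wide margin on both sides. The estimated step is a 1.2-fold lower number from compound 3 to compound 4 (0.08 log units; within the scatter). For compound 4 the expected value in this assay is 25000 nM, with an estimated range from 8000 nM to 85000 nM.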

Compound 4, half-maximal inhibitory concentration: 23400 nM
Compound 4: middle estimate off by 1.1-fold (0.03 log units), on the high side; the measured number falls inside the stated range.
By their numbers in this assay, from the lowest: compounds 4, 3 and 1 (each within the scatter of the next). At a limit, above all of these: compound 2.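

Compound 4 shows that this place also tolerates a group of a different kind. In this assay, going by these compounds alone, 1H-indol-3-yl brings a five-membered aromatic ring and a hydrogen-bond donor, yet swapping it in for 2-methoxyphenyl gives a 1.3-fold lower number from compound 3 to compound 4 (0.11 log units; within the scatter) and swapping it in for 4-hydroxyphenyl gives a 1.5-fold lower number from compound 1 to compound 4 (0.16 log units; within the scatter), so compounds 1, 3 and 4 cannot be told apart despite carrying three different groups here, whereas the earlier compounds had only substituted phenyl groups at this place. Swapping it in for 3,4-dimethoxyphenyl gives an at least 5.4-fold lower number from compound 2 to compound 4 (0.73 log units; beyond the scatter), which leaves compound 2 as the one compound set apart from the others, and its value is a limit and not a number: the limit of > 128000 nM in this assay, at which 1 of the 4 values shown sits.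

From the compounds shown here alone, it remains open whether an amine, a carboxylic acid or a longer chain at this place would keep the number in the same range or move it clearly. Also open, going by these compounds, is whether the hydrogen-bond donor of 1H-indol-3-yl matters at all, and what a pyridine ring, which has a ring nitrogen but no such hydrogen, would give here.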